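This account rests on a few compounds, and the source may have more. Where it says the series, first, only, none or still open, it means among the compounds named here.

Of the compounds shown here, three sharing one core have so far been tested in a functional assay on the whole organism (strain albino) for inhibition, with Rattus norvegicus as the target, read by paw edema, with stated times of 30 min and 1 h, at a dose of 0.28 mmol/kg by the oral route; a lower number here means less inhibition, a higher number more inhibition at the dose given (going by the name of the read-out). Compound 1 `C=CCn1c(SCC(=O)Nc2ccc(/C(C)=N/O)cc2)nnc1-c1ccccc1` gives 61%. Compound 2 `C/C(=N\O)c1ccc(NC(=O)CSc2nnc(-c3ccccc3)n2-c2ccccc2)cc1` gives 50%, and compound 3 `COc1ccc(-c2nnc(SCC(=O)Nc3ccc(/C(C)=N/O)cc3)n2-c2ccccc2)cc1OC` gives 57%. Among these three numbers compound 3 stands second highest, but its gaps to compound 1 and to compound 2 both lie within the usual scatter of repeated measurements, so no order among them can be claimed. The step of a number 7 percentage points higher from compound 2 to compound 3 (within the scatter) is likewise within the scatter. Going by the values given here, the only step beyond the scatter is a number 11 percentage points lower from compound 1 to compound 2 (beyond the scatter), a modest loss.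

Compound 4 `C=CCn1c(SCC(=O)Nc2ccc(/C(C)=N/O)cc2)nnc1-c1ccc(OC)c(OC)c1` has not yet been measured. It differs from compound 3 in one place: allyl in place of phenyl on an aromatic nitrogen. This is the reverse of the change that separates compound 1 from compound 2, so that step is the one that bears on it, and its reversal suggests a gain of similar size rather than none. For compound 4 the expected step is therefore a number 11 percentage points higher from compound 3 to compound 4 (beyond the scatter). The estimate for compound 4 is 68%, with a range from 58% to 78%.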

Compound 4, a percentage reported as inhibition, in the whole organism at one dose (the size of the read-out at that dose, not a potency): 53%
Compound 4: the middle estimate sits 15 percentage points above what was measured; measured number below the stated range.
By their numbers in this assay, from the lowest: compounds 2, 4, 3 and 1 (each within the scatter of the next, the first and the last beyond it).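

With the 3,4-dimethoxyphenyl group on the ring carbon, allyl in place of phenyl on the aromatic nitrogen brings no clear gain in this assay, with a number 4 percentage points lower from compound 3 to compound 4 (within the scatter). The effect of this change at the nitrogen therefore does not carry over from one core to the other: the same change on two cores in this assay, a number 11 percentage points lower (beyond the scatter) from compound 1 to compound 2 and a number 4 percentage points higher (within the scatter) from compound 4 to compound 3, 15 percentage points apart, beyond the scatter of two such steps. The change on the carbon also reads differently with allyl on the nitrogen, with a number 8 percentage points lower from compound 1 to compound 4 (within the scatter), so across these four compounds the two positions cannot be treated as independent: the same change on two cores in this assay, a number 7 percentage points higher (within the scatter) from compound 2 to compound 3 and a number 8 percentage points lower (within the scatter) from compound 1 to compound 4, 15 percentage points apart, beyond the scatter of two such steps.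

The four compounds carry only allyl or phenyl on the nitrogen, which leaves open how a methyl group, a longer chain such as hexyl or a chain ending in an amine would behave there. Readings at a single dose also leave open how these compounds compare in potency.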